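Nitro in place of fluoro on the pendant ring

The source may hold more compounds than are shown below. What is called first, only, known or untested is meant among the compounds shown, and "the series" means these compounds.

Three compounds share one core and differ only in the substituted ring attached to the amine nitrogen. Compound 1 `Nc1nc(N)c(CCCN(Cc2ccc(NC(CCC(=O)O)C(=O)O)cc2)c2cc(F)c([N+](=O)[O-])cc2[N+](=O)[O-])c(O)n1` carries two nitro groups on that ring, and in a functional assay on CCRF-CEM cells (Homo sapiens) for cytotoxicity, in the absence of a further agent (a lower number here means a stronger inhibitor, a higher number a weaker inhibitor), compound 1 gives 51000 nM. Compound 2 `Nc1nc(N)c(CCCN(Cc2ccc(NC(CCC(=O)O)C(=O)O)cc2)c2cc(F)c(F)cc2[N+](=O)[O-])c(O)n1` has a fluoro where compound 1 has one of its nitro groups; in this assay compound 2 gives > 100000 nM, which is a limit of the assay and not a number. Compound 3 `Nc1nc(N)c(CCCN(Cc2ccc(NC(CCC(=O)O)C(=O)O)cc2)c2ccc([N+](=O)[O-])c(F)c2F)c(O)n1` holds the same atoms as compound 2, joined differently: 2,3-difluoro-4-nitrophenyl in place of 4,5-difluoro-2-nitrophenyl on an amine nitrogen. In this assay compound 3 gives > 100000 nM, again a limit and not a number. The change from compound 2 to compound 1 is nitro in place of fluoro on an aromatic carbon and produced an at least 1.9-fold lower number from compound 2 to compound 1 (0.29 log units; that floor lies within the scatter). The step that the two limits leave unreadable from compound 2 to compound 3 cannot be sized because of the limit of > 100000 nM in this assay, at which 2 of the 3 values shown sit.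

Compound 4 `Nc1nc(N)c(CCCN(Cc2ccc(NC(CCC(=O)O)C(=O)O)cc2)c2ccc([N+](=O)[O-])c(F)c2[N+](=O)[O-])c(O)n1` has not yet been measured in this assay. It differs from compound 3 by nitro in place of fluoro on an aromatic carbon, the same kind of change as from compound 2 to compound 1, though here the entering nitro sits ortho to a large group and meta to a nitro group, whereas in compound 1 it sits meta to a nitro group and para to a large group. Since the earlier step reached only the floor of an at least 1.9-fold lower number from compound 2 to compound 1 (0.29 log units; that floor lies within the scatter), the expected step is an at least 1.6-fold lower number from compound 3 to compound 4 (0.22 log units; that floor lies within the scatter). Compound 4 is expected to give about 60000 nM in this assay, within a range from 20000 nM to 200000 nM.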

Compound 4, half-maximal inhibitory concentration: 46000 nM
Compound 4: the middle estimate sits 1.3-fold (0.12 log units) above what was measured; the measured number falls inside the stated range.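

In this assay, nitro in place of fluoro on the pendant ring gave an at least 2.1-fold lower number from compound 3 to compound 4 (0.33 log units; beyond the scatter), so on this second arrangement of the ring the step clears the usual scatter, which the floor of the first pair alone did not do. Set side by side, the two pairs point the same way, which is some support for carrying the change across, but they do not show that the step has the same size on both: the same change on two cores in this assay, an at least 1.9-fold lower number (0.29 log units; that floor lies within the scatter) from compound 2 to compound 1 and an at least 2.1-fold lower number (0.33 log units; beyond the scatter) from compound 3 to compound 4; the limit leaves it open whether they differ Neither step is a true measured size, only a floor, because each starts from a compound that gives a limit of the assay and not a number: the limit of > 100000 nM in this assay, at which 2 of the 4 values shown sit.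

On these data alone, it remains open whether nitro is special in this place, or whether a nitrile, a trifluoromethyl group or an amine in place of the same fluoro would lower the number as well. Also open, as far as these compounds go, is how far the change carries to a compound with a longer chain on the amine nitrogen, and what it does on a partner compound whose value lies within the range of the assay, where the full size of the step could be read.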